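This account rests on a few compounds, and the source may have more. Where it says the series, first, only, none or still open, it means among the compounds named here.

Compound 1 `Cc1ccc(-c2ccc(C)n2-c2ccc(-c3nc4ccccc4s3)cc2)cc1`: 4400 nM
Compound 2 `Cc1ccc(-c2ccc([N+](=O)[O-])cc2)n1-c1ccc(-c2nc3ccccc3s2)cc1`: 3900 nM

Both compounds were tested in a functional assay on MDA-MB-231 cells (Homo sapiens) for cytotoxicity, read by sulforhodamine B assay, with a stated time of 48 h; on this read-out higher numbers stand for weaker inhibition of growth and lower numbers for stronger inhibition of growth. Compound 2 gives 3900 nM and compound 1 gives 4400 nM; the step of a 1.1-fold lower number from compound 1 to compound 2 (0.05 log units; within the scatter) leaves the two numbers within the scatter of each other, so neither compound can be called stronger or weaker on these data.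

Compound 3 `COc1ccc2nc(-c3ccc(-n4c(C)ccc4-c4ccc([N+](=O)[O-])cc4)cc3)sc2c1` has not yet been measured. It differs from compound 2 in one place: methoxy in place of hydrogen on an aromatic carbon. Among the measured compounds shown here, the only measured step, a 1.1-fold lower number from compound 1 to compound 2 (0.05 log units; within the scatter), concerns a different part of the shared core and did not move the number beyond the scatter; no measured step touches the fused ring, so no direct precedent exists for this change. On that basis the step from compound 2 to compound 3 is expected to stay within the scatter, a 1.1-fold lower number from compound 2 to compound 3 (0.05 log units; within the scatter), with no direction favoured. The number expected for compound 3 in this assay is therefore 3500 nM, with a likely range from 1200 nM to 9000 nM.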

Compound 3, concentration for 50% growth inhibition: 4560 nM
Compound 3: middle estimate off by 1.3-fold (0.11 log units), on the low side, and the stated range covers the measured number.
By their numbers in this assay, from the lowest: compounds 2, 1 and 3 (each within the scatter of the next).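

In this assay, methoxy in place of hydrogen on an aromatic carbon gives a 1.2-fold higher number from compound 2 to compound 3 (0.07 log units; within the scatter). Among the compounds shown here, this is the first measured change on the six-membered aromatic ring of carbon only that is part of the fused system of two rings, as the earlier step concerned a different part of the shared core, and it shows that this carbon can carry methoxy, with its 2 heavy atoms and hydrogen-bond acceptor, without the number moving beyond the scatter, so neither compound 2 nor compound 3 can be called stronger or weaker. Nothing measured here explains why the number holds at this carbon.

The compounds shown leave open whether a different group on the same carbon, such as an amine, a carboxylic acid or a longer chain like butoxy, would move the number beyond the scatter. They also leave open whether methoxy would give a similar result on other carbons of this ring, or on the core of compound 1, which carries methyl where compound 3 carries nitro.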